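The source may hold more compounds than are shown below. What is called first, only, known or untested is meant among the compounds shown, and "the series" means these compounds.

Measured so far in a functional assay on MGC-803 cells (Homo sapiens) for inhibition, read by MTT assay; a lower number here means a stronger inhibitor, a higher number a weaker inhibitor:
- compound 1 `Cc1ccc(O)c(/C=N\NC(=O)c2oc3cccc(O)c3c2C)c1` gives 5990 nM
- compound 2 `Cc1c(C(=O)N/N=C\c2cccc(Br)c2O)oc2cccc(O)c12` gives 14200 nM
- compound 3 `Cc1c(C(=O)N/N=C\c2cc(Cl)ccc2O)oc2cccc(O)c12` gives 4160 nM

Compound 1 stands second highest of the three; compound 3 sits within scatter of it, a 1.4-fold lower number from compound 1 to compound 3 (0.16 log units; within the scatter), while compound 2 lies further off, a 2.4-fold higher number from compound 1 to compound 2 (0.37 log units; beyond the scatter).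

Compound 4 `Cc1c(C(=O)N/N=C\c2ccc(O)cc2O)oc2cccc(O)c12` differs from compound 1 only at the aryl group: 2,4-dihydroxyphenyl in place of 2-hydroxy-5-methylphenyl on a carbon with a double bond to nitrogen. For the measured compounds named here, the steps that bear on this are the aryl swaps, a 2.4-fold higher number from compound 1 to compound 2 (0.37 log units; beyond the scatter) and a 3.4-fold lower number from compound 2 to compound 3 (0.53 log units; beyond the scatter), both modest, and the within-scatter substituent change a 1.4-fold lower number from compound 1 to compound 3 (0.16 log units; within the scatter). Changes on that ring have so far moved this assay by small amounts in either direction, so no step beyond the scatter is firmly expected for compound 4.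

Compound 4 is therefore estimated at 6000 nM, range 2500 nM to 14000 nM, a step of a 1.0-fold higher number from compound 1 to compound 4 (0.00 log units; within the scatter) expected.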

Compound 4, half-maximal inhibitory concentration: 7330 nM
For compound 4 the middle estimate is 1.2-fold (0.09 log units) below the measured one, within the range that was stated.
By their numbers in this assay, from the lowest: compounds 3, 1, 4 and 2 (each within the scatter of the next, the first and the last beyond it).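

At the aryl group on a carbon with a double bond to nitrogen, 2,4-dihydroxyphenyl stays within the scatter of all three earlier aryl groups in this assay (a 1.2-fold higher number from compound 1 to compound 4 (0.09 log units; within the scatter)) (a 1.8-fold higher number from compound 3 to compound 4 (0.25 log units; within the scatter)) (a 1.9-fold lower number from compound 2 to compound 4 (0.29 log units; within the scatter)). Compound 4 therefore does not separate from either compound 2 or compound 3, although those two remain apart from each other. No accompanying data explain this result.

Going by these compounds, whether a methoxy group in place of the added hydroxyl, or an amine or carboxylic acid on this ring, would give a step beyond the scatter stays open.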